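The source may report more compounds than this note shows. Statements on the series, on what has been measured and on what is new or still open speak of the compounds shown alone.

The core of compound 1 `CCCCCCCC(=O)c1cc(O)c(O)c(O)c1` is shared by compound 2 `CCCCCCCCCCC(=O)c1cc(O)c(O)c(O)c1` and compound 3 `CCCCCCCCCCCC(=O)c1cc(O)c(O)c(O)c1`, which differ from it in their saturated chains. In an ADME assay on Vero cells (Chlorocebus sabaeus) for cytotoxicity (on this read-out higher numbers stand for weaker inhibition and lower numbers for stronger inhibition), compound 1 gives > 1000 nM, which is a limit and not a number. Compound 2 gives > 1000 nM, also a limit. Compound 3 stands at > 1000 nM, again a limit.

Compound 4 `CCCCCCCCCCCCC(=O)c1cc(O)c(O)c(O)c1` differs from compound 3 by methyl in place of hydrogen on a saturated chain carbon, ten or more bonds along the chain from a carbonyl carbon. The same change gave a step that the two limits leave unreadable from compound 2 to compound 3. Larger additions to the chain gave a step that the two limits leave unreadable from compound 1 to compound 2 and a step that the two limits leave unreadable from compound 1 to compound 3. All three compounds share one result: the limit of > 1000 nM in this assay, at which 3 of the 3 values shown sit.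

Among the compounds with values here, no measured step has a readable size, so no step beyond the scatter is expected in this assay. The expected step is a step that the limit leaves unreadable from compound 3 to compound 4. For compound 4, the estimate is 2000 nM, with an expected range from 800 nM to 10000 nM.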

Compound 4, half-maximal inhibitory concentration: > 1000 nM
Compound 4: a limit, no number; the forecaster's own chance of this, stated with the estimate: 85%; the middle value is on the limit's open side.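

In this assay compound 4 gives > 1000 nM, a limit and not a number, so its steps from compound 1, compound 2 and compound 3 cannot be read. The four compounds share one result: the limit of > 1000 nM in this assay, at which 4 of the 4 values shown sit.

From the compounds shown here alone, what stays open is where each true value lies, and whether the length of the saturated chain changes the result in this assay at all.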